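The source may hold more compounds than are shown below. What is called first, only, known or untested is meant among the compounds shown, and "the series" means these compounds.

Measured compounds:
compound 1 `CCOC(=O)c1c(-c2c(Cl)c3ccccc3oc2=O)nn(-c2ccccc2)c1C(=O)OCC` gives 100000 nM in a functional assay on HeLa cells (Homo sapiens) for cytotoxicity, read by MTT assay, with a stated time of 48 h; on this read-out higher numbers stand for weaker inhibition and lower numbers for stronger inhibition
compound 2 `CCOC(=O)c1c(-c2c(Cl)c3ccccc3oc2=O)nn(-c2cccc(C)c2)c1C(=O)OCC` gives 30000 nM in this assay
compound 3 `CCOC(=O)c1c(-c2cc3ccccc3oc2=O)nn(-c2ccccc2)c1C(=O)OCC` gives 100000 nM in this assay

Compound 3 stands level with compound 1 in this assay, the two together giving the highest numbers of the three; the step from compound 1 to compound 3, no change at the digits printed from compound 1 to compound 3 (within the scatter), shows that removing the chloro on the shared core left the read-out unchanged. Within the data shown here, compound 2 sits apart, with a 3.3-fold lower number from compound 1 to compound 2 (0.52 log units; beyond the scatter) marking the only step beyond the scatter in the set.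

Compound 4 `CCOC(=O)c1c(-c2cc3ccccc3oc2=O)nn(-c2cccc(C)c2)c1C(=O)OCC` is not yet measured. It differs from compound 3 by methyl in place of hydrogen on an aromatic carbon. Among the measured compounds shown here, the one measured step that bears on it is the same exchange on the chloro-bearing series, a 3.3-fold lower number from compound 1 to compound 2 (0.52 log units; beyond the scatter), a modest lowering of the number. Since the chloro itself made no difference, no change at the digits printed from compound 1 to compound 3 (within the scatter), the same size of step is expected here, in the same direction, as a 3.3-fold lower number from compound 3 to compound 4 (0.52 log units; beyond the scatter). Compound 4 is therefore estimated at 30000 nM, with a range from 10000 nM to 100000 nM.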

Compound 4, half-maximal inhibitory concentration: 245000 nM
Estimate against measurement, compound 4: 8.2-fold (0.91 log units) below; measured number above the stated range.
By their numbers in this assay, from the lowest: compound 2; then compounds 1 and 3 (each within the scatter of the next); then compound 4.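

The step from phenyl to 3-methylphenyl has no fixed direction in this assay: a 2.5-fold higher number from compound 3 to compound 4 (0.39 log units; beyond the scatter) runs opposite to the step seen on the chloro-bearing core: the same change on two cores in this assay, a 3.3-fold lower number (0.52 log units; beyond the scatter) from compound 1 to compound 2 and a 2.5-fold higher number (0.39 log units; beyond the scatter) from compound 3 to compound 4, 8.2-fold (0.91 log units) apart, beyond the scatter of two such steps The chloro, which made no difference on the phenyl compounds, matters on the 3-methylphenyl compounds, with hydrogen in its place giving an 8.2-fold higher number from compound 2 to compound 4 (0.91 log units; beyond the scatter): the same change on two cores in this assay, no change at the digits printed (within the scatter) from compound 1 to compound 3 and an 8.2-fold higher number (0.91 log units; beyond the scatter) from compound 2 to compound 4, 8.2-fold (0.91 log units) apart, beyond the scatter of two such steps The two changes therefore do not add independently here, and of the four compounds only compound 2 carries both the chloro and the methyl.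

Going by these compounds, whether this dependence on the chloro extends to other groups in place of the methyl, such as a methoxy or an amine, remains open. Also open, on these data alone, is whether a bromo or a nitrile in place of the chloro would pair with the methyl in the same way.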